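A few compounds are considered here, and "the series" means these few. Any claim that something is new, unique, unknown or untested is made for them only; others in the source may bear on it.

In a functional assay on HCT-116 cells (Homo sapiens) for inhibition (on this read-out lower numbers stand for stronger inhibition and higher numbers for weaker inhibition), compound 2 (`CCNC(=O)c1noc(-c2cc(C(C)C)c(O)cc2O)c1-c1cc(CNC(=O)CC)no1`) gives 78 nM and compound 1 (`CCCNCc1cc(-c2c(C(=O)NCC)noc2-c2cc(C(C)C)c(O)cc2O)on1`) gives 117 nM and so the two lie within the scatter of each other. Compound 3 (`CCNC(=O)c1noc(-c2cc(C(C)C)c(O)cc2O)c1-c1cc(CN2CCN(C)CC2)no1`) differs from compound 2 in one place, with 4-methylpiperazin-1-yl in place of propanoylamino on a saturated chain carbon bound to an aromatic carbon. Going by the values given here, the only measured step on this side chain is a 1.5-fold lower number from compound 1 to compound 2 (0.18 log units; within the scatter) and it lies within the scatter. Among the compounds with values here, no measured compound carries the 4-methylpiperazin-1-yl group, so that single step is thin evidence for this change. Neither direction is favoured, and no shift beyond the scatter is expected: the estimated change is a 1.3-fold higher number from compound 2 to compound 3 (0.11 log units; within the scatter) on these numbers. Compound 3 is estimated at 100 nM with an expected range of 40 nM to 280 nM in this read-out.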

Compound 3, half-maximal inhibitory concentration: 340 nM
For compound 3 the middle estimate is 3.4-fold (0.53 log units) below the measured one; measured number above the stated range.
By their numbers in this assay, from the lowest: compounds 2 and 1 (each within the scatter of the next); then compound 3.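

In this assay, going by these compounds alone, this place on a saturated chain carbon bound to an aromatic carbon proves sensitive to the group it carries: the change to 4-methylpiperazin-1-yl gives a 4.4-fold higher number from compound 2 to compound 3 (0.64 log units; beyond the scatter) and, set against propylamino, a 2.9-fold higher number from compound 1 to compound 3 (0.46 log units; beyond the scatter), whereas the one earlier step here stayed within the scatter. Compound 3 is also the only compound shown with a six-membered non-aromatic ring at this place, so tolerance of the propanoylamino and propylamino groups did not carry over to this ring. Nothing available explains the higher number.

The compounds shown do not separate the effect of the ring from that of its methyl-bearing second nitrogen. A morpholine, a piperidine or an open-chain dimethylamino group at this place would help to tell these apart.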